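The compounds below may be only part of what the source reports. "The series", "measured", "known", "first", "only" and "open" are said of these compounds alone.

Compound 1 `CC(C)(Oc1ccc(Cl)cc1)C(=O)Nc1nc(-c2ccccc2)n[nH]1` gives 41% in an assay on CHO cells for inhibition of adenosine receptor A1 (Homo sapiens), read by scintillation counting, with a stated time of 60 min, tested at 10 uM; on this read-out higher numbers stand for more inhibition at the one concentration tested (going by the name of the read-out) and lower numbers for less inhibition
Compound 2 `O=C(COc1ccccc1)Nc1nc(-c2ccccc2)n[nH]1` gives 20%
Compound 3 `O=C(COc1ccc2c(c1)CCC2)Nc1nc(-c2ccccc2)n[nH]1` gives 46%

Of these three numbers, compound 2 stands lowest: compound 1 lies higher by a margin beyond the usual scatter, and compound 3 higher still, also beyond the scatter. Compound 4 `O=C(COc1ccccc1)Nc1nc(-c2ccc(F)cc2)n[nH]1` has not been measured. It differs from compound 2 in a single place: fluoro in place of hydrogen on an aromatic carbon. For the measured compounds named here, no measured pair shows this particular change, so nothing in the numbers at hand tells how large its effect might be. The expected step is therefore small, with no clear direction, and most likely within the scatter of repeated measurements. Compound 4 is estimated to give about 22%, with a range from 5% to 40%. That estimate corresponds to an expected step of a number 2 percentage points higher from compound 2 to compound 4 (within the scatter).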

Compound 4, a percentage reported as inhibition, at one concentration (the size of the read-out at that concentration, not a potency): 2%
Estimate against measurement, compound 4: 20 percentage points above, and the stated range ends above it.
By their numbers in this assay, from the lowest: compound 4; then compound 2; then compounds 1 and 3 (each within the scatter of the next).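

A single fluoro on the phenyl ring is enough to change the result in this assay (a number 18 percentage points lower from compound 2 to compound 4 (beyond the scatter)). For the compounds shown here, this position, para to a large group, is therefore sensitive to even one added heavy atom, something no earlier pair could show, since none isolated this position. Nothing available explains why the number falls.

As far as these compounds go, it remains open whether a different group here, such as an amine or a methoxy group, would lower the number further or raise it. Whether fluoro would give a similar step on compound 1 or compound 3 is also unknown.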